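The compounds below may be only part of what the source reports. "The series", "measured", "known", "first", "only" and "open" are said of these compounds alone.

Measured compounds:
compound 1, `CCCCC/N=C(\NC#N)Nc1cccnc1`: 20 mg/kg
compound 2, `CC(C)CC/N=C(\NC#N)Nc1cccnc1`: 20 mg/kg

Both compounds share one core and differ only in the chain attached to the double-bonded nitrogen. In a functional assay on the whole organism (blood, strain Wistar-Okamoto) with Rattus norvegicus as the target, with a stated time of 5 days (on this read-out higher numbers stand for an effect only at larger amounts of compound and lower numbers for an effect already at smaller amounts), compound 1 gives 20 mg/kg. In this assay compound 2 gives 20 mg/kg. The step of no change at the digits printed from compound 1 to compound 2 (within the scatter) shows that exchanging one chain for another of this kind left the dose unchanged, so compound 2 stands level with compound 1 on the numbers available.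

Compound 3, `CC(C)/N=C(\NC#N)Nc1cccnc1`, is the next compound in this line. It differs from compound 2 by isopropyl in place of isopentyl on a double-bonded nitrogen. Going by the values given here, only one measured step exists, no change at the digits printed from compound 1 to compound 2 (within the scatter), and it concerns a different kind of change in the same chain, so it offers no direct measure of what the present change does. It does suggest that the chain on the double-bonded nitrogen can be altered without moving the dose. On that basis compound 3 is expected to show a step of a 1.5-fold higher number from compound 2 to compound 3 (0.18 log units; within the scatter), that is, no change beyond the scatter. Compound 3 is therefore estimated at 30 mg/kg in this assay, with a range from 10 mg/kg to 100 mg/kg.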

Compound 3, minimum effective dose: 2.5 mg/kg
Beside the measured number, compound 3's estimate is 12-fold (1.08 log units) above it; measured number outside the range, below it.
By their numbers in this assay, from the lowest: compound 3; then compounds 1 and 2 (each within the scatter of the next).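

In this assay, the chain on a double-bonded nitrogen turns out to matter: isopropyl in place of isopentyl gives an 8.0-fold lower number from compound 2 to compound 3 (0.90 log units; beyond the scatter), and isopropyl in place of pentyl gives an 8.0-fold lower number from compound 1 to compound 3 (0.90 log units; beyond the scatter), so a lower dose is enough to produce the effect with isopropyl at this place. The earlier pair showed only that two chains of 5 carbons, pentyl and isopentyl, stand level, which made the chain look unimportant; going down to the 3 carbons of isopropyl shows that this holds only for that one exchange, not for the position as a whole. Nothing available here explains why this change lowers the dose.

Going by these compounds, with only three chains to compare, it remains open whether the lower number goes with the smaller count of carbons or with the isopropyl shape itself, and a straight propyl chain at this place would help tell these apart. On these data alone, how far the trend continues, for example with an ethyl or a tert-butyl group, or with a chain carrying an amine, is also open.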